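The source may hold more compounds than are shown below. What is called first, only, known or untested is meant among the compounds shown, and "the series" means these compounds.

Among the measured compounds shown here, in a functional assay on MDA-MB-231 cells (Homo sapiens) for cytotoxicity, read by MTT assay, with a stated time of 24 h (a higher number here means a weaker inhibitor, a lower number a stronger inhibitor), three compounds have numbers so far. Compound 1 `NCC(=O)NCc1nnc(-c2ccc(F)cc2)o1` gives 254 nM, compound 2 `Cc1ccc(-c2nnc(CNC(=O)CN)o2)cc1` gives 260 nM, and compound 3 `Cc1ccc(-c2nnc(CNC(=O)[C@@H](C)N)o2)cc1` gives 254 nM. Compound 3 thus stands level with the other two, and all three values lie within the scatter of one another.

Compound 4 `C[C@@H](N)C(=O)NCc1nnc(-c2ccc([N+](=O)[O-])cc2)o1` has not yet been measured. It differs from compound 3 in one place: nitro in place of methyl on an aromatic carbon. In words, this is nitro in place of methyl on an aromatic carbon, para to a large group.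

For the measured compounds named here, two measured steps bear on this change. The closer one also swaps a group on an aromatic carbon: a 1.0-fold higher number from compound 1 to compound 2 (0.01 log units; within the scatter), with methyl in place of fluoro, and it stays within the scatter. The other, a 1.0-fold lower number from compound 2 to compound 3 (0.01 log units; within the scatter), adds a methyl on the saturated chain carbon and also stays within the scatter. Neither step involves a nitro group, so the data offer only indirect guidance and the range must stay wide.

On this basis, no shift beyond the scatter is expected, and the estimated change is a 1.0-fold lower number from compound 3 to compound 4 (0.01 log units; within the scatter). For compound 4, the expected value is 250 nM, with an estimated range from 100 nM to 600 nM.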

Compound 4, half-maximal inhibitory concentration: 261 nM
Beside the measured number, compound 4's estimate is 1.0-fold (0.02 log units) below it; measured number inside the range.
By their numbers in this assay, from the lowest: compounds 1, 3, 2 and 4 (each within the scatter of the next).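

In this assay, nitro in place of methyl on the aromatic carbon gives a 1.0-fold higher number from compound 3 to compound 4 (0.01 log units; within the scatter). A group of 3 heavy atoms with 2 hydrogen-bond acceptors thus replaces a methyl of 1 heavy atom, with no hydrogen-bond acceptors, and the step stays within the scatter; the earlier step at this place, methyl in place of fluoro, did not test a group of this kind. No measurement shown here accounts for why the number stays within the scatter across this swap.

The groups seen on this aromatic carbon are still only fluoro, methyl and nitro, and each comparison rests on a single pair of compounds in a single assay, so no general rule for this place can be drawn yet. Going by these compounds, whether a carboxylic acid or an amine on this aromatic carbon, or a longer chain in place of the methyl on the saturated chain carbon, would produce a step beyond the scatter remains open.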